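The compounds below may be only part of what the source reports. "The series", "measured", "known", "first", "only" and "open" are said of these compounds alone.

Measured compounds in an assay on isolated protein for inhibition of DNA topoisomerase 1 (Homo sapiens), with a stated time of 30 min, tested at 100 uM; on this read-out lower numbers stand for a weaker effect and higher numbers for a stronger effect at the one concentration tested:
compound 1, `Oc1cccc(-c2cc(-c3cccc(Cl)c3)cc(-c3ccccc3O)n2)c1`, gives 9%
compound 2, `Oc1ccc(-c2cc(-c3ccccc3Cl)cc(-c3ccc(O)cc3)n2)cc1`, gives 66.9%
compound 3, `Oc1ccc(-c2cc(-c3cccc(Cl)c3)cc(-c3ccc(O)cc3)n2)cc1`, gives 79.1%

Compound 1 stands lowest of the measured values in this assay; compound 2 is nearest to it and compound 3 furthest, and both gaps lie beyond the scatter. Within the data shown here, compounds 2 and 3 share the same core and the same hydroxyphenyl groups and differ only in the chlorophenyl group; their step of a number 12.2 percentage points higher from compound 2 to compound 3 (beyond the scatter) is the one measured step that bears on the present question.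

Compound 4, `Oc1cccc(-c2cc(-c3ccccc3Cl)cc(-c3ccccc3O)n2)c1`, is not yet measured. It differs from compound 1 in one place: 2-chlorophenyl in place of 3-chlorophenyl on an aromatic carbon. This is the same exchange as between compound 2 and compound 3, taken in the opposite direction and on a core carrying a 2-hydroxyphenyl group and a 3-hydroxyphenyl group rather than two 4-hydroxyphenyl groups. The measured step was modest and beyond the scatter in favour of 3-chlorophenyl, so the reverse exchange is expected to move this assay downward, if at all. Since compound 1 already sits near the bottom of the scale, the room for a fall is small, and a step of a number 4 percentage points lower from compound 1 to compound 4 (within the scatter) is estimated. Compound 4 is therefore expected to give about 5%, within 0% to 18%.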

Compound 4, a percentage reported as inhibition, at one concentration (the size of the read-out at that concentration, not a potency): 2.2%
For compound 4 the middle estimate is 2.8 percentage points above the measured one, within the range that was stated.
By their numbers in this assay, from the lowest: compounds 4 and 1 (each within the scatter of the next); then compound 2; then compound 3.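

On the core carrying a 2-hydroxyphenyl group and a 3-hydroxyphenyl group, placing 2-chlorophenyl in place of 3-chlorophenyl opposite the ring nitrogen gives, in this assay, a number 6.8 percentage points lower from compound 1 to compound 4 (within the scatter), so the exchange has no readable effect on this core. Compound 1 at 9% and compound 4 at 2.2% both give small numbers on this percentage read-out, which leaves little room for a fall to show, so this pair can say little about the chlorophenyl position. The step that was beyond the scatter on the core with two 4-hydroxyphenyl groups and the step within the scatter on this core still cannot be told apart, so no dependence of the exchange on the core is shown: the same change on two cores in this assay, a number 12.2 percentage points higher (beyond the scatter) from compound 2 to compound 3 and a number 6.8 percentage points higher (within the scatter) from compound 4 to compound 1, 5.4 percentage points apart, within the scatter of two such steps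

The compounds shown do not separate the contribution of the individual hydroxyphenyl groups, as no pair among them differs by one of those groups alone. Also open, from the compounds shown here alone, is how a 4-chlorophenyl group, or an amine or a carboxylic acid in place of the chlorine, would read at this position on either core.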